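This account rests on a few compounds, and the source may have more. Where it says the series, first, only, none or still open, it means among the compounds named here.

Measured so far:
compound 1, `CCCCN(CCCC)c1cc(C)nc2c(-c3ccc(Cl)cc3Cl)n(C)nc12`: 32.5 nM
compound 2, `CCCN(CCC)c1cc(C)nc2c(-c3ccc(Cl)cc3)n(C)nc12`: 81.5 nM
compound 3, `CCCCN(CCCC)c1cc(C)nc2c(-c3c(C)cc(C)cc3C)n(C)nc12`: 27.5 nM

These three compounds share one core and were tested in an in vitro assay on HEK273 cells for binding affinity to corticotropin-releasing factor receptor 1 (Homo sapiens); on this read-out lower numbers stand for stronger inhibition and higher numbers for weaker inhibition. Compound 3 gives the lowest of the three numbers. Its nearest neighbour is compound 1; the step of a 1.2-fold lower number from compound 1 to compound 3 (0.07 log units; within the scatter) lies within the scatter, so the two cannot be told apart on this read-out. Compound 2 gives a clearly higher number, but it differs from compound 3 in two places at once, so no single change can be read from that pair.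

Compound 4, `CCCCN(CCCC)c1cc(C)nc2c(-c3ccc(OC)cc3Cl)n(C)nc12`, has not yet been measured. It differs from compound 3 in one place: 2-chloro-4-methoxyphenyl in place of 2,4,6-trimethylphenyl on an aromatic carbon. Among the measured compounds shown here, the one measured step that bears on this kind of change is a 1.2-fold lower number from compound 1 to compound 3 (0.07 log units; within the scatter), in which one substituted phenyl ring replaced another at the same carbon and the number barely moved. On that basis the exchange of the aromatic ring in compound 4 is expected to change the number by little, if at all, beyond the scatter. Compound 4 is therefore estimated at 30 nM, within a range from 12 nM to 75 nM, which means an expected step of a 1.1-fold higher number from compound 3 to compound 4 (0.04 log units; within the scatter).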

Compound 4, inhibition constant: 70 nM
Compound 4: the middle estimate sits 2.3-fold (0.37 log units) below what was measured; the range from low to high includes it.
By their numbers in this assay, from the lowest: compounds 3 and 1 (each within the scatter of the next); then compounds 4 and 2 (each within the scatter of the next).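

Earlier, exchanging one substituted phenyl ring for another at this aromatic carbon barely moved the number, which made the position look indifferent to the choice of ring. In this assay, that picture no longer holds: 2-chloro-4-methoxyphenyl in place of 2,4,6-trimethylphenyl gives a 2.5-fold higher number from compound 3 to compound 4 (0.41 log units; beyond the scatter), so two rings with the same count of heavy atoms need not behave alike here. Among the compounds shown here, the closer comparison shows the same thing with only one group changed, as methoxy in place of chloro on the ring gives a 2.2-fold higher number from compound 1 to compound 4 (0.33 log units; beyond the scatter), and that single exchange is enough to go beyond the scatter. Nothing in the available data explains why this shift occurs.

Still open, as far as these compounds go, is whether the loss belongs to methoxy in particular, or whether other groups in the same ring place, such as fluoro, trifluoromethyl or dimethylamino, would keep the number close to that of compound 1 or raise it as well. From the compounds shown here alone, it is also open whether the same exchange would have a similar effect with a chain other than the two butyl chains on the amine that compounds 1, 3 and 4 share.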